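Toward Compound 4: A Sulfamoylphenyl Variant of Compound 3

The compounds below may be only part of what the source reports. "The series", "measured", "known", "first", "only" and "open" are said of these compounds alone.

Compound 1 `COc1ccc(CNC(=O)c2nc(-c3ccc(F)cc3)n(CC[C@@H](O)C[C@@H](O)CC(=O)O)c2C2CC2)cc1F`: 0.2 nM
Compound 2 `Cc1ccc(CNC(=O)c2nn(-c3ccc(F)cc3)c(CC[C@@H](O)C[C@@H](O)CC(=O)O)c2C(C)C)cc1`: 0.9 nM
Compound 3 `O=C(O)C[C@H](O)C[C@H](O)CCn1c(-c2ccc(F)cc2)nc(C(=O)NCc2ccccc2F)c1C1CC1`: "not determined" (no result reported)

In a functional assay on cells (Hepatocyte, Rattus norvegicus) for inhibition, read by scintillation counting, with a stated time of 4 h (on this read-out higher numbers stand for weaker inhibition and lower numbers for stronger inhibition), compound 1 gives 0.2 nM, and compound 2 gives 0.9 nM. Compound 3 shares its core with compound 1. In this assay compound 3 has no result and so no number to stand on; compound 3 is reported only as "not determined" (no result reported). Compound 4 `CN(C)S(=O)(=O)c1ccc(CNC(=O)c2nc(-c3ccc(F)cc3)n(CC[C@@H](O)C[C@@H](O)CC(=O)O)c2C2CC2)cc1` differs from compound 3 by 4-(dimethylsulfamoyl)phenyl in place of 2-fluorophenyl on a saturated chain carbon bound to an amide-type nitrogen. Among the measured compounds shown here, as no step between measured compounds is given, the size of the change in this assay cannot be read from the data; the expectation is a step within or near the scatter, in no firm direction. On the values of compound 1 and compound 2, compound 4 is expected to give 1 nM in this assay, within 0.2 nM to 8 nM.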

Compound 4, half-maximal inhibitory concentration: 0.5 nM
Compound 4: middle estimate off by 2.0-fold (0.30 log units), on the high side, within the range that was stated.
By their numbers in this assay, from the lowest: compound 1; then compounds 4 and 2 (each within the scatter of the next).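

In this assay, among the compounds shown here, the first readable step at this position, on a saturated chain carbon bound to an amide-type nitrogen, is a 2.5-fold higher number from compound 1 to compound 4 (0.40 log units; beyond the scatter), with 4-(dimethylsulfamoyl)phenyl in place of 3-fluoro-4-methoxyphenyl. The step is modest, and compound 4 still gives 0.5 nM, so this position tolerates the sulfamoyl-bearing ring with only a limited loss. Nothing available accounts for the step.

The step from compound 3 cannot be read, since compound 3 has no result. On these data alone, whether an amine or a carboxylic acid on that phenyl ring would be tolerated equally remains open.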